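Swapping an aryl ketone ether for a phenyl carbamate

The source may hold more compounds than are shown below. What is called first, only, known or untested is meant among the compounds shown, and "the series" means these compounds.

Compound 1 `CC1(C)C=C(n2ccccc2=O)c2cc(O)ccc2O1` carries a free hydroxyl on its aromatic ring, and in a functional assay (trachea) with Rattus norvegicus as the target (on this read-out higher numbers stand for higher potency (the scale is a negative logarithm) and lower numbers for lower potency), compound 1 gives 5.31. For the measured compounds named here, compound 2 `CC1(C)C=C(n2ccccc2=O)c2cc(OCC(=O)c3ccc(F)cc3)ccc2O1` replaces that hydrogen with ((4-fluorophenyl)carbonyl)methyl; in this assay compound 2 gives 4.77, the lowest of the two numbers measured, and the only comparison available shows a number 0.54 log units lower from compound 1 to compound 2 (beyond the scatter). Compound 3 `CC1(C)C=C(n2ccccc2=O)c2cc(OC(=O)Nc3ccccc3)ccc2O1` is the compound to be measured, and it differs from compound 2 by phenylcarbamoyl in place of ((4-fluorophenyl)carbonyl)methyl on an oxygen on an aromatic ring. Going by the values given here, only the step from compound 1 to compound 2 bears on this change, and it concerns a different pair of groups, so it gives no direct guide. Because compound 2 sits at 4.77 with a group of similar size already on that oxygen, the expected step is small, a number 0.13 log units higher from compound 2 to compound 3 (within the scatter), within or just beyond the scatter. Compound 3 is therefore estimated at 4.9, with a range from 4.3 to 5.5.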

Compound 3, logarithm of the reciprocal of the active concentration, log(1/C): 4.89
Estimate against measurement, compound 3: 0.01 log units above; low and high end bracket the measured number.
By their numbers in this assay, from the lowest: compounds 2 and 3 (each within the scatter of the next); then compound 1.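

In this assay, replacing ((4-fluorophenyl)carbonyl)methyl with phenylcarbamoyl on the oxygen gives a number 0.12 log units higher from compound 2 to compound 3 (within the scatter), so this assay does not separate the two groups, even though phenylcarbamoyl carries a hydrogen-bond donor and the group it replaces does not. Measured against the free hydroxyl, the new group gives a number 0.42 log units lower from compound 1 to compound 3 (beyond the scatter), so the lower number is no longer seen with ((4-fluorophenyl)carbonyl)methyl alone: two different groups on this oxygen now fall below compound 1. No measurement available here explains these numbers.

As far as these compounds go, it remains open whether a much smaller group, such as methyl, or a chain ending in an amine or a carboxylic acid, would stay close to compound 1. The role of the amide hydrogen could be tested with an N-methyl-N-phenylcarbamoyl group, which lacks it.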